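Urea series: methoxy to isopropyl on the phenyl ring

This account rests on a few compounds, and the source may have more. Where it says the series, first, only, none or still open, it means among the compounds named here.

Measured so far in an assay on isolated protein for inhibition of vascular endothelial growth factor receptor 2 (Danio rerio), read by fluorescence and microscopy, with a stated time of 33 h; a lower number here means a stronger inhibitor, a higher number a weaker inhibitor:
compound 1 `Cc1cccc(NC(=O)Nc2ccc(Nc3ncnc4[nH]ncc34)cc2)c1C`, a limit of the assay, > 100000 nM
compound 2 `COc1cccc(NC(=O)Nc2ccc(Oc3ncnc4[nH]ncc34)cc2)c1`, 82000 nM
compound 3 `COc1cccc(NC(=O)Nc2ccc(Oc3ncnc4c3cnn4C)cc2)c1`, a limit of the assay, > 100000 nM

Among the compounds with values here, compound 2 stands as the only actual number in this assay; the other two values are limits (the limit of > 100000 nM in this assay, at which 2 of the 3 values shown sit). Within the data shown here, the one measured step, an at least 1.2-fold higher number from compound 2 to compound 3 (0.08 log units; that floor lies within the scatter), lies within the scatter and concerns the core, not the phenyl ring.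

Compound 4 `CC(C)c1cccc(NC(=O)Nc2ccc(Oc3ncnc4[nH]ncc34)cc2)c1` differs from compound 2 by isopropyl in place of methoxy on an aromatic carbon. Among the measured compounds shown here, no measured step touches this ring, so nothing supports a step beyond the scatter in this assay; compound 4 is expected near compound 2. For compound 4 the estimate is 85000 nM, within 30000 nM to 250000 nM, which means an expected step of a 1.0-fold higher number from compound 2 to compound 4 (0.02 log units; within the scatter).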

Compound 4, half-maximal inhibitory concentration: 7730 nM
Beside the measured number, compound 4's estimate is 11-fold (1.04 log units) above it; measured number outside the range, below it.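

The position meta to a large group on this aromatic ring responds to substitution: in this assay, isopropyl in place of methoxy gives an 11-fold lower number from compound 2 to compound 4 (1.03 log units; beyond the scatter). Within the data shown here, this is the first step beyond the scatter, as the only earlier step concerned the core and stayed within it. The hydrogen-bond acceptor of methoxy is not required at this place for the lower number.

Which part of the change carries the step stays open, and an amine or a tert-butyl group at this place would bear on that. Few actual numbers are available for comparison: the limit of > 100000 nM in this assay, at which 2 of the 4 values shown sit.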